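A few compounds are considered here, and "the series" means these few. Any claim that something is new, unique, unknown or untested is made for them only; others in the source may bear on it.

Measured compounds:
compound 1 `c1ccc2c(c1)CN[C@@H](CN(CCCN1CCNCC1)[C@H]1CCCc3cccnc31)C2` gives 17 nM in a functional assay on CCRF-CEM cells for antagonist activity at C-X-C chemokine receptor type 4 (Homo sapiens), read by calcium flux, with stated times of 25 min and 90 s; a higher number here means a weaker inhibitor, a lower number a stronger inhibitor
compound 2 `c1ccc2c(c1)CN[C@@H](CN(CC[C@@H]1CCCNC1)[C@H]1CCCc3cccnc31)C2` gives 161 nM

Of these two numbers, compound 2 gives the highest, so on the evidence so far it is the weaker inhibitor; its nearest neighbour is compound 1, which differs from it in one place. Compound 3 `CCN1CCN(CCCN(C[C@H]2Cc3ccccc3CN2)[C@H]2CCCc3cccnc32)CC1` has not yet been measured. It differs from compound 2 by (4-ethylpiperazin-1-yl)methyl in place of piperidin-3-yl on a saturated chain carbon, two bonds along the chain from an amine nitrogen. For the measured compounds named here, only one measured step bears on this change: a 9.5-fold higher number from compound 1 to compound 2 (0.98 log units; beyond the scatter), which is the reverse of the present change except for the ethyl group on the far ring nitrogen. Returning to a piperazinylmethyl group is therefore expected to bring the number back down by a step of similar size, and compound 3 is expected to be a stronger inhibitor than compound 2 in this assay, with an expected step of a 6.4-fold lower number from compound 2 to compound 3 (0.81 log units; beyond the scatter). The estimate for compound 3 is 25 nM, within 8 nM to 80 nM.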

Compound 3, half-maximal inhibitory concentration: 33 nM
Estimate against measurement, compound 3: 1.3-fold (0.12 log units) below; low and high end bracket the measured number.
By their numbers in this assay, from the lowest: compounds 1 and 3 (each within the scatter of the next); then compound 2.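

In this assay the move from piperidin-3-yl to (4-ethylpiperazin-1-yl)methyl gives a 4.9-fold lower number from compound 2 to compound 3 (0.69 log units; beyond the scatter) and so shows that the low number returns with an ethyl group present on the piperazine ring. Adding that ethyl in place of hydrogen on an amine nitrogen in a ring gives a 1.9-fold higher number from compound 1 to compound 3 (0.29 log units; within the scatter) with no change beyond the scatter, so a hydrogen on that nitrogen is not needed for a low number in this assay. Nothing available here explains these differences.

On these data alone, it remains open how much bulk that ring nitrogen tolerates, as a benzyl group or an acetyl group there could behave differently from ethyl. The three compounds also leave open whether a longer chain leading to the piperazine ring would keep the number low.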